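The source may hold more compounds than are shown below. What is called first, only, known or untested is meant among the compounds shown, and "the series" means these compounds.

Of the compounds shown here, two with a shared core have been tested in a functional assay on HCT-116 cells (Homo sapiens) for antiproliferative activity, read by MTT assay; a higher number here means a weaker inhibitor, a lower number a stronger inhibitor. Compound 1 `Cn1c(=O)c(=O)n(C2CCCC2)c2nc(N/N=C/c3ccc(F)cc3Cl)ncc21` gives 13800 nM. Compound 2 `COc1ccc(/C=N/Nc2ncc3c(n2)n(C2CCCC2)c(=O)c(=O)n3C)cc1` gives 36100 nM, the higher of the two numbers, separated from compound 1 by a 2.6-fold higher number from compound 1 to compound 2 (0.42 log units; beyond the scatter). Compound 3 `Cn1c(=O)c(=O)n(C2CCCC2)c2nc(N/N=C/c3cc([N+](=O)[O-])ccc3Cl)ncc21` is not yet measured; it differs from compound 2 in that (2-chloro-5-nitrophenyl in place of 4-methoxyphenyl on a carbon with a double bond to nitrogen). Among the measured compounds shown here, only that single step bears on this change, and in the group concerned compound 3 resembles compound 1 more than compound 2. The expected step is a 2.4-fold lower number from compound 2 to compound 3 (0.38 log units; beyond the scatter), roughly the earlier size but downward. For compound 3 the estimate is 15000 nM, within 5000 nM to 45000 nM.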

Compound 3, half-maximal inhibitory concentration: 5610 nM
The estimate for compound 3 lay 2.7-fold (0.43 log units) above the measured number, within the range that was stated.
By their numbers in this assay, from the lowest: compound 3; then compound 1; then compound 2.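

Replacing 4-methoxyphenyl with 2-chloro-5-nitrophenyl on this carbon gives a 6.4-fold lower number from compound 2 to compound 3 (0.81 log units; beyond the scatter) in this assay and shows that this position can move the number further than the first pair did. The same group in place of 2-chloro-4-fluorophenyl gives a 2.5-fold lower number from compound 1 to compound 3 (0.39 log units; beyond the scatter) so the two chlorine-bearing groups also differ from each other. Nothing available explains either step. Still open, as far as these compounds go, is how an amine or a carboxylic acid on this aromatic ring would compare, and what the nitro group would do without the chlorine.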